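From butyl to cyclopentyl on the sulfur of compound 3

The source may hold more compounds than are shown below. What is called first, only, known or untested is meant among the compounds shown, and "the series" means these compounds.

In an ADME assay on MT4 cells (Homo sapiens) for activation, read by MTT assay (a lower number here means that less compound is tolerated, a higher number that more compound is tolerated), compound 3 `CCCCSc1nc(C(C)c2c(F)cccc2Cl)c(C)c(=O)[nH]1` gives > 1500 nM as a limit and not a number. Compound 2 `Cc1c(C(C)c2c(F)cccc2Cl)nc(SC(C)C)[nH]c1=O` gives > 15000 nM as a limit too. No exact value is available for either compound. Compound 4 `Cc1c(C(C)c2c(F)cccc2Cl)nc(SC2CCCC2)[nH]c1=O` carries cyclopentyl in place of butyl on a sulfur. Within the data shown here, the one measured step on that sulfur is a step that the two limits leave unreadable from compound 2 to compound 3 and so offers no size to carry over. The closest guide is compound 1 `CC(c1cc(=O)[nH]c(SC2CCCC2)n1)c1c(F)cccc1Cl`, which also carries cyclopentyl on a sulfur. Compound 1 gives > 71000 nM as a limit in this assay and not as a number. All three results are therefore limits, and none of them shows a measured change in either direction. No step beyond the scatter can be predicted with confidence, and a further limit is the likeliest report. The expected result is a step that the limit leaves unreadable from compound 3 to compound 4 on these numbers. For compound 4 the estimate is 40000 nM with an expected range from 5000 nM to 200000 nM in this assay.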

Compound 4, half-maximal cytotoxic concentration: > 15000 nM
Compound 4 gave a limit, no number (the forecaster's own chance of this, stated with the estimate: 80%); the middle value does not contradict the limit.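

In this assay, among these compounds, compound 4 gives a limit and not a number, as do compound 1, compound 2 and compound 3, so no step to compound 4 can be read. The compounds shown leave open whether cyclopentyl, butyl or isopropyl on the sulfur changes the tolerated concentration at all.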